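A few compounds are considered here, and "the series" means these few. Any claim that something is new, unique, unknown or untested is made for them only; others in the source may bear on it.

Compound 2 `CC(C)=CCC/C(C)=C/CC1Cc2c(O)cc(=O)n(CCCO)c2CC1(C)C` is tested in a functional assay on PANC-1 cells (Homo sapiens) for inhibition, read by MTT assay, with a stated time of 24 h, tested at 10 uM (a higher number here means more inhibition at the concentration tested (going by the name of the read-out), a lower number less inhibition), where compound 2 gives 0%. It stands level with compound 1 `CC(C)=CCC1Cc2c(O)cc(=O)n(CCCO)c2CC1(C)C`, which in this assay gives 0%, and with compound 3 `CC(C)=CCC1Cc2c(OCCCOc3ccc([N+](=O)[O-])cc3)cc(=O)n(CCCO)c2CC1(C)C`, which in this assay gives 0%. Going by the values given here, the one step between measured compounds, from compound 1 to compound 2, gave no change at the digits printed from compound 1 to compound 2 (within the scatter), so a change to the side chain left the read-out unmoved. Compound 4 `COc1ccc(OCCCOc2cc(=O)n(CCCO)c3c2CC(C/C=C(\C)CCC=C(C)C)C(C)(C)C3)cc1` differs from compound 2 by 3-(4-methoxyphenoxy)propyl in place of hydrogen on an oxygen on an aromatic ring. Among the compounds with values here, no measured step touches that oxygen, and nothing among the three compounds moves beyond the scatter, so no step beyond it is expected: from compound 2 to compound 4 the estimated change is no change at the digits printed from compound 2 to compound 4 (within the scatter). For compound 4 the estimate in this assay is 0%, with a range from 0% to 12%.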

Compound 4, a percentage reported as inhibition, at one concentration (the size of the read-out at that concentration, not a potency): 0%
Compound 4: middle estimate and measured number agree at the digits printed; low and high end bracket the measured number.
By their numbers in this assay, from the lowest: compounds 1, 2, 3 and 4 (each within the scatter of the next).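

Going by these compounds alone, the first measured step at this oxygen, 3-(4-methoxyphenoxy)propyl in place of hydrogen, gave in this assay no change at the digits printed from compound 2 to compound 4 (within the scatter). Within the data shown here, compound 2 already stands at 0%, so the step shows only that this group does not raise the read-out on the longer side chain; any loss could not appear. From the compounds shown here alone, whether an amine or a carboxylic acid on that oxygen, or a longer chain there, would lift the read-out stays open. No evidence at hand bears on this result.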